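This account rests on a few compounds, and the source may have more. Where it says the series, first, only, none or still open, it means among the compounds named here.

In an assay (Cavia porcellus) for inhibition of Polyunsaturated fatty acid 5-lipoxygenase (Homo sapiens) (a lower number here means a stronger inhibitor, a higher number a weaker inhibitor), compound 1, with the structure `NC(=O)N(O)CC1=Cc2cc(OCc3ccccc3)ccc2OC1`, gives 380 nM. Among the measured compounds shown here, only one other compound has been measured alongside it: compound 2, with the structure `CCOC(=O)CNC(=O)N(O)CC1=Cc2cc(Oc3ccccc3)ccc2OC1`, gives in this assay 74 nM. Of these two numbers, compound 1 has the higher one, and the gap between compound 1 and compound 2 lies beyond the usual scatter of this kind of measurement. For the measured compounds named here, compound 2 differs from compound 1 in more than one place, so the two values show only that compound 1 is the weaker inhibitor of the pair, not which part of the structure accounts for the gap.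

Compound 3, with the structure `NC(=O)N(O)CC1=Cc2cc(-c3ccccc3)ccc2OC1`, has not yet been measured. It differs from compound 1 in a single place: phenyl in place of benzyloxy on an aromatic carbon. Going by the values given here, no measured pair in this set isolates such an exchange, so nothing measured tells how large a step it brings. The step from compound 1 to compound 3 is expected to be small, a 1.3-fold higher number from compound 1 to compound 3 (0.12 log units; within the scatter), most likely no larger than the scatter itself. For compound 3 the expected value in this assay is 500 nM, within a range from 150 nM to 1700 nM.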

Compound 3, half-maximal inhibitory concentration: 230 nM
The estimate for compound 3 lay 2.2-fold (0.34 log units) above the measured number; low and high end bracket the measured number.
By their numbers in this assay, from the lowest: compound 2; then compounds 3 and 1 (each within the scatter of the next).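

Among the compounds shown here, the exchange of benzyloxy for phenyl on this aromatic carbon, which no earlier pair isolated, gives a 1.7-fold lower number from compound 1 to compound 3 (0.22 log units; within the scatter) in this assay and so stays within the scatter. The group that leaves has 8 heavy atoms and 1 hydrogen-bond acceptor, and the group that enters has 6 heavy atoms and no hydrogen-bond acceptor, yet both bring one six-membered aromatic ring of carbon only, and in this pair the difference between them does not separate the two numbers. Nothing measured here speaks to what lies behind this result.

As far as these compounds go, it remains open whether an amine, a carboxylic acid or a longer chain ending in phenyl on this same aromatic carbon would also stay within the scatter of compound 1. Also open is which part of compound 2, which gives 74 nM in this assay and differs from compound 1 and from compound 3 in more than one place, accounts for its number.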